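Thiosemicarbazones of a quinoline aldehyde: arylation of the terminal nitrogen

The source may hold more compounds than are shown below. What is called first, only, known or untested is meant among the compounds shown, and "the series" means these compounds.

Compound 1, `Fc1ccccc1NC(=S)N/N=C/c1ccc2ccccc2n1` — in a functional assay on HeLa cells (Homo sapiens) for antiproliferative activity, read by sulforhodamine B assay, with a stated time of 72 h (a lower number here means a stronger inhibitor, a higher number a weaker inhibitor), compound 1 gives > 100000 nM, a limit of the assay.
Compound 2, `S=C(NCc1ccccc1)N/N=C/c1ccc2ccccc2n1` — in this assay compound 2 gives 62800 nM.
Compound 3, `NC(=S)N/N=C/c1ccc2cccnc2n1` — in this assay compound 3 gives > 100000 nM, a limit of the assay.

Among the three measured compounds, compound 2 is the only one that returns a number in this assay; the other two sit at the limit of > 100000 nM in this assay, at which 2 of the 3 values shown sit. For the measured compounds named here, the single measured step that touches compound 2 is an at least 1.5-fold lower number from compound 1 to compound 2 (0.20 log units; that floor lies within the scatter), a benzyl taking the place of a 2-fluorophenyl on the amide-type nitrogen; its floor lies within the scatter, so the benzyl compound is at most modestly better than the aryl one.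

Compound 4, `COc1cccc(NC(=S)N/N=C/c2ccc3ccccc3n2)c1`, is to be measured in this assay. It differs from compound 2 by 3-methoxyphenyl in place of benzyl on an amide-type nitrogen. This change brings back an aryl group on the same nitrogen, the kind of substituent carried by compound 1. Because compound 1 gives > 100000 nM and the step from it to compound 2 is small, compound 4 is expected to land near or back at the limit, and the expected step is a 1.6-fold higher number from compound 2 to compound 4 (0.20 log units; within the scatter). The estimate for compound 4 is 100000 nM, with a range from 40000 nM to 300000 nM.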

Compound 4, half-maximal inhibitory concentration: 74500 nM
Estimate against measurement, compound 4: 1.3-fold (0.13 log units) above; low and high end bracket the measured number.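

With 3-methoxyphenyl on the amide-type nitrogen, an aryl group at this position now returns a number in this assay, and that number cannot be told apart from the one given by benzyl: a 1.2-fold higher number from compound 2 to compound 4 (0.07 log units; within the scatter). Against the other aryl group, 2-fluorophenyl, the change gives an at least 1.3-fold lower number from compound 1 to compound 4 (0.12 log units; that floor lies within the scatter), so the two aryl groups cannot be ranked on this reading either. No step among these three groups on this nitrogen is shown to lie beyond the scatter, and the limit of the assay still holds part of the set: the limit of > 100000 nM in this assay, at which 2 of the 4 values shown sit.

As far as these compounds go, what stays open is whether any group on this nitrogen can move the number beyond the scatter, for instance a longer chain such as phenethyl or a chain ending in an amine. Equally open, from the compounds shown here alone, is whether the oxygen of the 3-methoxyphenyl group counts at all, which a plain phenyl on the same nitrogen would test.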